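A few compounds are considered here, and "the series" means these few. Any claim that something is new, unique, unknown or untested is made for them only; others in the source may bear on it.

Compound 1 `CCn1c(C(=O)NC2(CO)CC2)ccc1C(CC)(CC)c1ccc(OCS(=O)(=O)c2ccccc2)c(C)c1`: 45400 nM
Compound 2 `CCn1c(C(=O)N[C@@H](CO)C(C)C)ccc1C(CC)(CC)c1ccc(OCS(=O)(=O)c2ccccc2)c(C)c1`: 13200 nM

Of the compounds shown here, two have been measured in a functional assay on BXPC-3 cells (Homo sapiens) for antiproliferative activity, read by MTT assay, with a stated time of 24 h; on this read-out higher numbers stand for weaker inhibition and lower numbers for stronger inhibition. Compound 1 gives 45400 nM, and compound 2 gives 13200 nM. For the measured compounds named here, of these two numbers, compound 2 has the lower one; the single measured step of a 3.4-fold lower number from compound 1 to compound 2 (0.54 log units; beyond the scatter) separates them.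

Compound 3 `CCn1c(C(=O)NC2(C(=O)O)CC2)ccc1C(CC)(CC)c1ccc(OCS(=O)(=O)c2ccccc2)c(C)c1` has not been measured. It differs from compound 2 in one place: 1-carboxycyclopropyl in place of 1-(hydroxymethyl)-2-methylpropyl on an amide-type nitrogen. The 1-(hydroxymethyl)-2-methylpropyl group that compound 2 carries on the amide-type nitrogen gives way to a 1-carboxycyclopropyl group.

Going by the values given here, only one measured step bears on this change, and only in part. The step of a 3.4-fold lower number from compound 1 to compound 2 (0.54 log units; beyond the scatter) showed that exchanging a 1-(hydroxymethyl)cyclopropyl group for the 1-(hydroxymethyl)-2-methylpropyl group lowered the number. Among the compounds with values here, compound 3 brings back a three-membered ring on that nitrogen, so part of that step may be undone, but no measured pair shows what a carboxy group in place of a hydroxymethyl group does. The expected step is therefore a modest rise in number, with wide uncertainty: a 2.3-fold higher number from compound 2 to compound 3 (0.36 log units; beyond the scatter). Compound 3 is expected to give about 30000 nM, between 10000 nM and 100000 nM.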

Compound 3, half-maximal inhibitory concentration: > 50000 nM
Compound 3 was reported as a limit; the forecaster's own chance of this, stated with the estimate: 15%; middle value at least 1.6-fold (0.22 log units) from the limit.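

In this assay, compound 3 stands only as a limit of the assay and not as a number: the limit of > 50000 nM in this assay, at which 1 of the 3 values shown sits. Even so, the change on the amide-type nitrogen from 1-(hydroxymethyl)-2-methylpropyl to 1-carboxycyclopropyl can be read in one direction, as an at least 3.7-fold higher number from compound 2 to compound 3 (0.57 log units; beyond the scatter), so the new group does not match the group it replaces and this position is shown to respond to more than the change of ring alone. The comparison that isolates the new feature, carboxy in place of hydroxymethyl on a saturated ring carbon, gives an at least 1.1-fold higher number from compound 1 to compound 3 (0.04 log units; that floor lies within the scatter), so the limit leaves it unresolved whether that exchange lowers activity at all on the cyclopropyl ring.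

The compounds shown leave open how much of the rise in number belongs to the three-membered ring and how much to the carboxy group, a split that a 1-carboxy-2-methylpropyl group on the same nitrogen would help to settle. On these data alone, it also remains open how a methyl ester or a primary amide in place of the carboxy group would read on this ring.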